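The compounds below may be only part of what the source reports. "The series", "measured", "known", "first", "only" and "open" are said of these compounds alone.

Working notes on the series built on the shared core of compound 1 `N#CCn1c2ccc([N+](=O)[O-])cc2c(=O)n1Cc1ccccc1`, which carries a cyanomethyl group on the aromatic nitrogen. In an ADME assay on L929 cells (Mus musculus) for cytotoxicity, read by resazurin assay, with a stated time of 48 h (on this read-out higher numbers stand for lower toxicity in this test and lower numbers for higher toxicity in this test), compound 1 gives only a limit, > 256000 nM. Compound 2 `CN(C)C(=O)CCCn1c2ccc([N+](=O)[O-])cc2c(=O)n1Cc1ccccc1` likewise sits at a limit, > 256000 nM in this assay. Among the compounds with values here, compound 3 `CCOC(=O)n1c2ccc([N+](=O)[O-])cc2c(=O)n1Cc1ccccc1`, with ethoxycarbonyl on the aromatic nitrogen, gives 122000 nM in this assay, the only number in the set. Since (the limit of > 256000 nM in this assay, at which 2 of the 3 values shown sit), compound 1 stands at the top of the range shown rather than at a known number, and the step that the two limits leave unreadable from compound 1 to compound 2 cannot be sized. The steps of an at least 2.0-fold lower number from compound 1 to compound 3 (0.32 log units; beyond the scatter) and an at least 2.0-fold lower number from compound 2 to compound 3 (0.32 log units; beyond the scatter) are the ones with a readable size, both toward higher toxicity.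

Compound 4 `CC(=O)n1c2ccc([N+](=O)[O-])cc2c(=O)n1Cc1ccccc1` differs from compound 1 by acetyl in place of cyanomethyl on an aromatic nitrogen. The step of an at least 2.0-fold lower number from compound 1 to compound 3 (0.32 log units; beyond the scatter) bears most directly, as both changes put a carbonyl-bearing group on the aromatic nitrogen in place of cyanomethyl. For compound 4 a step of similar size and direction is expected, an at least 1.7-fold lower number from compound 1 to compound 4 (0.23 log units; that floor lies within the scatter). Compound 4 is therefore estimated at 150000 nM, in the range 50000 nM to 300000 nM, with a fair chance that this assay again reports only a limit.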

Compound 4, concentration lethal to 50% of the cells: > 256000 nM
Compound 4: no number, only a limit; the forecaster's own chance of this, stated with the estimate: 35%; middle value at least 1.7-fold (0.23 log units) from the limit.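

In this assay, methyl in place of ethoxy on the carbonyl carbon gives an at least 2.0-fold higher number from compound 3 to compound 4 (0.32 log units; beyond the scatter), so the lower number of compound 3 does not extend to every carbonyl-bearing group at this aromatic nitrogen. Among the compounds shown, ethoxycarbonyl in compound 3 is the only group on this nitrogen that gives a number rather than a limit. The steps from compound 1 and from compound 2 to compound 4 cannot be read, and compound 4 gives only a limit, as does most of the set: the limit of > 256000 nM in this assay, at which 3 of the 4 values shown sit.

No order can be set among compound 1, compound 2 and compound 4. Going by these compounds, it also remains open whether a longer ester such as butoxycarbonyl, or a carbamoyl group carrying an amine on this nitrogen, would behave like ethoxycarbonyl or like acetyl.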